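The source may hold more compounds than are shown below. What is called first, only, known or untested is meant among the compounds shown, and "the series" means these compounds.

Compound 1, `COc1ccc(-c2cc(/C=C/C(=O)c3ccc(N)cc3)[nH]n2)cc1`: 94%
Compound 2, `COc1cc(-c2cc(/C=C/C(=O)c3ccc(N)cc3)[nH]n2)cc(OC)c1OC`: 92%
Compound 3, `COc1ccc(C(=O)/C=C/c2cc(-c3cc(OC)c(OC)c(OC)c3)n[nH]2)cc1`: 97%

In a functional assay on SR cells (Homo sapiens) for cytotoxicity, read by sulforhodamine B assay, with a stated time of 48 h, tested at 0.01 uM (on this read-out higher numbers stand for a weaker effect at the one concentration tested and lower numbers for a stronger effect), the three measured compounds sit close together. Compound 2 gives the value at the low end of the group, but its gap to compound 1 is within the scatter, and the move to compound 3, a number 5 percentage points higher from compound 2 to compound 3 (within the scatter), is within the scatter as well, so nothing separates the three beyond the noise of the assay.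

Compound 4, `COc1ccc(-c2cc(/C=C/C(=O)c3ccc(N)cc3)[nH]n2)cc1OC`, is reached from compound 2 by one change: hydrogen in place of methoxy on an aromatic carbon. For the measured compounds named here, no measured pair shows the loss of a methoxy group; the only recorded step, from compound 2 to compound 3, replaces an amino with a methoxy on the other aromatic ring and stays within the scatter. With the three numbers so tightly clustered, the expectation for compound 4 is a step of a number 1 percentage points higher from compound 2 to compound 4 (within the scatter), that is, no movement beyond the scatter. Compound 4 is therefore estimated at 93% in this assay, with a range from 84% to 101%.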

Compound 4, a percentage reported as activity, at one concentration (the size of the read-out at that concentration, not a potency): 98%
Compound 4: middle estimate off by 5 percentage points, on the low side, and the stated range covers the measured number.
By their numbers in this assay, from the lowest: compounds 2, 1, 3 and 4 (each within the scatter of the next).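

In this assay, for the compounds shown here, the exchange of methoxy and hydrogen on this ring now has measured steps, which the earlier compounds lacked. Taking away the methoxy group that sits ortho to a methoxy group and meta to a large group gives a number 6 percentage points higher from compound 2 to compound 4 (within the scatter), and adding a methoxy group to the same ring gives a number 4 percentage points higher from compound 1 to compound 4 (within the scatter), so in both directions the change stays within the scatter at the one concentration tested. No evidence is available to explain these small steps.

The compounds shown leave open whether a different group at this position, such as a hydroxyl, a fluorine atom or an amine, would move the read-out beyond the scatter. They also leave open whether compound 2 and compound 4 would separate at a higher concentration.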